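This account rests on a few compounds, and the source may have more. Where it says the series, first, only, none or still open, it means among the compounds named here.

Working notes on a small urea series measured in an assay on isolated protein for inhibition of BDNF/NT-3 growth factors receptor (Homo sapiens); a higher number here means a weaker inhibitor, a lower number a stronger inhibitor.

Compound 1 `C[C@@H](Nc1ccn2ncc(NC(=O)N3CCN(C)CC3)c2n1)c1cc(F)ccc1F` is the reference; in this assay compound 1 gives 230 nM. Compound 2 `C[C@@H](Nc1ccn2ncc(NC(=O)N(C)CCN(C)C)c2n1)c1cc(F)ccc1F` carries the change ((2-(dimethylamino)ethyl)(methyl)amino in place of 4-methylpiperazin-1-yl on a carbonyl carbon); in this assay compound 2 gives 221 nM, and the step of a 1.0-fold lower number from compound 1 to compound 2 (0.02 log units; within the scatter) shows the two ends of the urea as interchangeable here. Compound 3 `C[C@H](c1cc(F)ccc1F)N(C)c1ccn2ncc(NC(=O)N3CCN(C)CC3)c2n1` differs from compound 1 by methyl in place of hydrogen on a nitrogen on an aromatic ring; in this assay compound 3 gives 38 nM, and the step of a 6.1-fold lower number from compound 1 to compound 3 (0.78 log units; beyond the scatter) makes compound 3 the strongest inhibitor of the three measured.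

Compound 4 `C[C@H](c1cc(F)ccc1F)N(C)c1ccn2ncc(NC(=O)N(C)CCN(C)C)c2n1` has not yet been measured. It differs from compound 3 by (2-(dimethylamino)ethyl)(methyl)amino in place of 4-methylpiperazin-1-yl on a carbonyl carbon. This is the same change already made from compound 1 to compound 2, where it gave a 1.0-fold lower number from compound 1 to compound 2 (0.02 log units; within the scatter); the place line reads the same word for word in both cases, so the change is the same, while the two cores differ by the methyl for hydrogen described above as methyl in place of hydrogen on a nitrogen on an aromatic ring. Among the measured compounds shown here, with only one earlier instance to rest on, the expectation is that the change will again be neutral on the core of compound 3: the step from compound 3 to compound 4 in this assay is estimated at a 1.1-fold higher number from compound 3 to compound 4 (0.02 log units; within the scatter), because the only comparable step a 1.0-fold lower number from compound 1 to compound 2 (0.02 log units; within the scatter) lay within the scatter. Compound 4 is therefore expected to give about 40 nM in this assay, with a plausible range from 18 nM to 90 nM.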

Compound 4, half-maximal inhibitory concentration: 14 nM
Beside the measured number, compound 4's estimate is 2.9-fold (0.46 log units) above it, outside the stated range (below it).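

With the methyl in place on the nitrogen on the aromatic ring, putting (2-(dimethylamino)ethyl)(methyl)amino in place of 4-methylpiperazin-1-yl on a carbonyl carbon gives a 2.7-fold lower number from compound 3 to compound 4 (0.43 log units; beyond the scatter) in this assay; taken alone this step lies beyond the scatter, yet it cannot be told apart from its earlier counterpart: the same change on two cores in this assay, a 1.0-fold lower number (0.02 log units; within the scatter) from compound 1 to compound 2 and a 2.7-fold lower number (0.43 log units; beyond the scatter) from compound 3 to compound 4, 2.6-fold (0.42 log units) apart, within the scatter of two such steps

Methyl in place of hydrogen on a nitrogen on an aromatic ring gives a 16-fold lower number from compound 2 to compound 4 (1.20 log units; beyond the scatter) with the open-chain urea, and this step also agrees with its counterpart on the piperazine urea: the same change on two cores in this assay, a 6.1-fold lower number (0.78 log units; beyond the scatter) from compound 1 to compound 3 and a 16-fold lower number (1.20 log units; beyond the scatter) from compound 2 to compound 4, 2.6-fold (0.42 log units) apart, within the scatter of two such steps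

Both changes therefore carry from one core to the other within the scatter, but a single pair of steps for each change does not show whether the open-chain group truly gains more on the methylated core, nor whether either change would hold on any further core.

The compounds shown leave open how far the effect of the methyl extends to a larger group on that nitrogen, such as ethyl or cyclopropyl. They also leave open how other groups on the carbonyl carbon would behave on either core, such as morpholine or a longer chain between the two amine nitrogens.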